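The compounds below may be only part of what the source reports. "The series", "measured", "known", "first", "only" and "open" are said of these compounds alone.

Two diaryl ureas built on the same pyrazole core have been tested so far. Compound 1 `O=C(Nc1cccc(-n2cc(-c3ccncc3)c(-c3cc(O)cc(Cl)c3)n2)c1)Nc1ccc(Cl)c(Cl)c1` gives 59% in a functional assay on MDA-MB-468 cells (Homo sapiens) for inhibition, read by sulforhodamine B assay, with a stated time of 48 h, tested at 1 uM; on this read-out higher numbers stand for a weaker effect at the one concentration tested and lower numbers for a stronger effect. Compound 2 `COc1cc(Cl)cc(-c2nn(-c3cccc(NC(=O)Nc4ccc(Cl)c(C(F)(F)F)c4)c3)cc2-c2ccncc2)c1` gives 50% in the same assay. Compound 2 thus carries the lower of the two numbers, but the gap to compound 1 lies within the usual scatter of this assay, so the two compounds cannot be told apart on these data.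

Compound 3 `COc1cc(Cl)cc(-c2nn(-c3cccc(NC(=O)Nc4ccc(Cl)c(Cl)c4)c3)cc2-c2ccncc2)c1` differs from compound 2 in one place: chloro in place of trifluoromethyl on an aromatic carbon. Among the measured compounds shown here, with no pair of measured compounds sharing this change, there is nothing to say about its size from experience. The expected step from compound 2 to compound 3 in this assay is a number 4 percentage points higher from compound 2 to compound 3 (within the scatter), that is, no change beyond the scatter. Compound 3 is therefore estimated to give about 54% in this assay, within a range from 34% to 74%.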

Compound 3, a percentage reported as activity, at one concentration (the size of the read-out at that concentration, not a potency): 69%
For compound 3 the middle estimate is 15 percentage points below the measured one; low and high end bracket the measured number.
By their numbers in this assay, from the lowest: compounds 2, 1 and 3 (each within the scatter of the next, the first and the last beyond it).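

Among the compounds shown here, replacing the 4-chloro-3-(trifluoromethyl)phenyl group with 3,4-dichlorophenyl gives the first step in this assay that exceeds the scatter: a number 19 percentage points higher from compound 2 to compound 3 (beyond the scatter), which on this read-out means a weaker effect at the one concentration tested. This single pair shows that the group at this position can matter, whereas the change on the oxygen, methyl in place of hydrogen, gives a number 10 percentage points higher from compound 1 to compound 3 (within the scatter) and so cannot be read as a real difference. Nothing at hand explains the step from trifluoromethyl to chloro.

As far as these compounds go, whether the same step would hold with a hydrogen rather than a methyl on the oxygen remains open. Also open, from the compounds shown here alone, is how a methyl, a bromo or a nitrile would compare at this position, and whether a longer chain such as ethyl on the oxygen would leave the read-out unchanged.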